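The source may report more compounds than this note shows. Statements on the series, on what has been measured and on what is new or still open speak of the compounds shown alone.

Working notes on the series. Among the measured compounds shown here, compound 1 `CC(=O)NCCN(C)c1cccc(OCCCCCCNC(=O)Oc2cccc(-c3ccccc3)c2)c1` gives 0.75 in a functional assay on cells for agonist activity at melatonin receptor type 1B (Homo sapiens), read by GTPgammaS binding, with a stated time of 30 min (on this read-out higher numbers stand for larger maximal responses and lower numbers for smaller maximal responses), the highest of the three numbers measured so far. The nearest measured compound is compound 3 `CC(=O)NCCN(C)c1cccc(OCCCCCCOc2cccc(O)c2)c1`, which gives 0.57 in this assay, a gap that lies beyond the scatter. The furthest is compound 2 `CC(=O)NCCN(C)c1cccc(OCCCCCCN)c1`, which gives 0.08 in this assay. For the measured compounds named here, the single step measured within one place of difference is a number 0.49 higher from compound 2 to compound 3 (beyond the scatter), where a 3-hydroxyphenoxy replaces an amino on a saturated chain carbon, six bonds along the chain from an oxygen on an aromatic ring.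

Compound 4 `CC(=O)NCCN(C)c1cccc(OCCCCCCNC(=O)Oc2cccc(-c3cccc(O)c3)c2)c1` is not yet measured. Compared with compound 1, it carries hydroxy in place of hydrogen on an aromatic carbon, on an aromatic carbon of a six-membered aromatic ring of carbon only. Going by the values given here, no measured step puts a hydroxy in place of a hydrogen on an aromatic ring; the one measured step adds a whole 3-hydroxyphenoxy in place of amino, a far larger change, so it bears only loosely on the present one. Among the compounds with values here, the terminal aryl group in compound 3 already carries a hydroxy and that compound sits below compound 1, but that pair differs in more than one place and no step is computed for it. A step within the scatter, or a small one in either direction, is therefore expected for this assay, a number 0.050 lower from compound 1 to compound 4 (within the scatter). The estimate for compound 4 in this assay is 0.7, with a range from 0.55 to 0.85.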

Compound 4, intrinsic activity: the largest response reached, as a fraction of the reference agonist's: 0.94
Beside the measured number, compound 4's estimate is 0.24 below it, and the stated range ends below it.
By their numbers in this assay, from the lowest: compound 2; then compound 3; then compound 1; then compound 4.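

In this assay there is a number 0.19 higher from compound 1 to compound 4 (beyond the scatter) on the change from phenyl to 3-hydroxyphenyl, so a single added hydroxy raises the maximal response beyond the scatter when it sits on an aromatic carbon, meta to a large group. The earlier step replaced amino with a whole 3-hydroxyphenoxy, whereas this one changes only one heavy atom and shows that the end ring of compound 1 still responds to a change of this small size. Nothing measured here on the hydroxy or on the compounds accompanies the step, so the rise has no stated explanation.

It remains open whether the hydroxy itself is needed, since the compounds shown include no methoxy, amine or carboxylic acid in the same place on this ring, and so do not show whether another group would give a similar step. On these data alone, it is also open whether the gain persists on a longer chain, or with the hydroxy placed elsewhere on this ring.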